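Restoring the piperazine arm on the shared core

A few compounds are considered here, and "the series" means these few. Any claim that something is new, unique, unknown or untested is made for them only; others in the source may bear on it.

In a functional assay on HL-60 cells (Homo sapiens) for inhibition, read by MTT assay, with a stated time of 72 h (a lower number here means a stronger inhibitor, a higher number a weaker inhibitor), compound 2 `Cc1ccc(-c2nnc(-c3ccc(F)c(C(F)(F)F)c3)o2)cc1Nc1nccc(-c2cccnc2)n1` is reported only as a limit, > 30000 nM, so its standing among the measured values is known as a limit and not as a number. Compound 1 `Cc1ccc(-c2nnc(-c3ccc(CN4CCN(C)CC4)c(C(F)(F)F)c3)o2)cc1Nc1nccc(-c2cccnc2)n1` gives 50 nM in this assay. For the measured compounds named here, the single measured step, an at least 600-fold higher number from compound 1 to compound 2 (2.77 log units; beyond the scatter), is the only one that bears on the change examined here; it is large, and its upper end rests on (the limit of > 30000 nM in this assay, at which 1 of the 2 values shown sits).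

Compound 3 `Cc1ccc(-c2nnc(-c3ccc(CN4CCN(CCN=C=S)CC4)c(C(F)(F)F)c3)o2)cc1Nc1nccc(-c2cccnc2)n1` is compound 2 with a group of 12 heavy atoms (8 carbon, 3 nitrogen, 1 sulfur; one six-membered non-aromatic ring with 2 hetero atoms) in place of one fluorine atom, on an aromatic carbon. The entering group brings back a six-membered non-aromatic ring with 2 hetero atoms of the kind compound 1 carries at the same aromatic carbon, though with a different substituent on that ring. Since compound 1 gives 50 nM and the removal of its related group produced an at least 600-fold higher number from compound 1 to compound 2 (2.77 log units; beyond the scatter), the reverse change is expected to recover most of that loss, with an at least 370-fold lower number from compound 2 to compound 3 (2.57 log units; beyond the scatter) expected to be large and downward. For compound 3 the estimate in this assay is 80 nM, within 20 nM to 600 nM.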

Compound 3, half-maximal inhibitory concentration: 70 nM
For compound 3 the middle estimate is 1.1-fold (0.06 log units) above the measured one, and the stated range covers the measured number.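

The arm on this aromatic carbon, para to a large group and ortho to a trifluoromethyl group, now has a second example, and the large step seen on removing it also appears in the other direction when a differently substituted piperazine replaces fluoro: an at least 420-fold lower number from compound 2 to compound 3 (2.63 log units; beyond the scatter). The size of that step has only one firm end, as it rests on a limit for compound 2: the limit of > 30000 nM in this assay, at which 1 of the 3 values shown sits. The substituent on the far ring nitrogen tolerates a real change in this assay, as the isothiocyanate-bearing ethyl chain in place of methyl stays within the scatter, a 1.4-fold higher number from compound 1 to compound 3 (0.15 log units; within the scatter), so the two piperazine compounds cannot be told apart here and the activity does not depend on the methyl group as such.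

As far as these compounds go, with only fluoro and two piperazine arms at this carbon, it remains open whether the ring as a whole or a single amine nitrogen carries the effect, which a morpholine or an open-chain dimethylaminomethyl group would separate. From the compounds shown here alone, whether the isothiocyanate end adds anything of its own also stays open, and a plain ethyl or a hydroxyethyl on the ring nitrogen would bear on that.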